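Alkyne substituent exchanges in the shared core

The source may hold more compounds than are shown below. What is called first, only, known or untested is meant among the compounds shown, and "the series" means these compounds.

Three members of the series have been run in an assay on CHO cells for displacement of a labelled ligand from adenosine receptor A1 (Homo sapiens), read by scintillation counting, with a stated time of 60 min, tested at 10 uM; on this read-out lower numbers stand for less inhibition and higher numbers for more inhibition at the one concentration tested (going by the name of the read-out). Compound 1 `CNC(=O)[C@@]12C[C@@H]1[C@@H](n1cnc3c(NC)nc(C#Cc4ccccc4)nc31)[C@H](O)[C@@H]2O` gives 18%. Compound 2 `CNC(=O)[C@@]12C[C@@H]1[C@@H](n1cnc3c(NC)nc(C#Cc4ccc(Cl)cc4)nc31)[C@H](O)[C@@H]2O` gives 13%, and compound 3 `CNC(=O)[C@@]12C[C@@H]1[C@@H](n1cnc3c(NC)nc(C#Cc4cccnn4)nc31)[C@H](O)[C@@H]2O` gives 11%. Each pair is separated by less than the usual scatter: a number 5 percentage points lower from compound 1 to compound 2 (within the scatter), a number 7 percentage points lower from compound 1 to compound 3 (within the scatter) and a number 2 percentage points lower from compound 2 to compound 3 (within the scatter). Compound 3 therefore stands together with the other two rather than apart from them; none of the three is distinguished from the others in this assay.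

Compound 4 `CNC(=O)[C@@]12C[C@@H]1[C@@H](n1cnc3c(NC)nc(C#CC4CC4)nc31)[C@H](O)[C@@H]2O` has not yet been measured. It differs from compound 3 in one place: cyclopropyl in place of pyridazin-3-yl on a triple-bonded carbon. Among the compounds with values here, the steps that bear on this change are the ones that exchange the group on the triple-bonded carbon, namely a number 7 percentage points lower from compound 1 to compound 3 (within the scatter) and a number 2 percentage points lower from compound 2 to compound 3 (within the scatter); both lie within the scatter, and the step of a number 5 percentage points lower from compound 1 to compound 2 (within the scatter) likewise moved nothing beyond it. No exchange made so far in this series has shifted the number beyond the scatter, so for compound 4 a step of a number 1 percentage points higher from compound 3 to compound 4 (within the scatter) is expected, which is to say none that would stand out from the scatter. Compound 4 is estimated at 12%, with a range from 2% to 28%.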

Compound 4, a percentage reported as inhibition, at one concentration (the size of the read-out at that concentration, not a potency): 38%
Beside the measured number, compound 4's estimate is 26 percentage points below it; measured number outside the range, above it.
By their numbers in this assay, from the lowest: compounds 3, 2 and 1 (each within the scatter of the next); then compound 4.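

At the triple-bonded carbon, the read-out of this assay responds to the exchange of group, a response the earlier exchanges among aromatic rings did not show: the steps to cyclopropyl read (a number 27 percentage points higher from compound 3 to compound 4 (beyond the scatter)) from pyridazin-3-yl, (a number 25 percentage points higher from compound 2 to compound 4 (beyond the scatter)) from 4-chlorophenyl and (a number 20 percentage points higher from compound 1 to compound 4 (beyond the scatter)) from phenyl. Among these four compounds the split is clean, with no compound against it: the three carrying a six-membered aromatic ring at this place stay within the scatter of each other, while compound 4, with its three-membered non-aromatic ring of carbon only, stands apart from all of them. Within the data shown here, nothing measured so far accounts for this separation.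

On these data alone, whether the rise belongs to cyclopropyl alone or extends to other non-aromatic groups at this place remains open, and a cyclobutyl or cyclohexyl ring, an open propyl chain or a dimethylaminomethyl group would test that. As far as these compounds go, the reading also remains a size at one concentration rather than a potency, so how far compound 4 stands from the other three in potency on this receptor stays unknown.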